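Liver microsome clearance notes: from compound 1 toward compound 4

The source may report more compounds than this note shows. Statements on the series, on what has been measured and on what is new or still open speak of the compounds shown alone.

Measured in an ADME assay on microsomes from liver (Homo sapiens) for metabolic stability; on this read-out higher numbers stand for fast clearance and lower numbers for slow clearance:
- compound 1, `CC(C)n1cc(-c2ccnc3[nH]c(C4CCN(CC(=O)N(C)C)CC4)cc23)cnc1=O`: compound 1 gives 24 uL/min
- compound 2, `CC(C)Cn1cc(-c2ccnc3[nH]c(C4CCN(CC(=O)N(C)C)CC4)cc23)ccc1=O`: compound 2 gives 21 uL/min
- compound 3, `CN(C)C(=O)CN1CCC(c2cc3c(-c4ccc(=O)n(CCC5CCOCC5)c4)ccnc3[nH]2)CC1`: compound 3 gives 19 uL/min

Compound 1 holds the highest of the three numbers, yet its nearest neighbour compound 2 and its furthest neighbour compound 3 both sit within the usual scatter, so the three measured compounds cannot be ordered on this assay.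

Compound 4, `COc1cc(=O)n(C)cc1-c1ccnc2[nH]c(C3CCN(CC(=O)N(C)C)CC3)cc12`, awaits measurement. Relative to compound 1 the change is a group of 10 heavy atoms (7 carbon, 1 nitrogen, 2 oxygen; one six-membered aromatic ring with 1 hetero atom) in place of a group of 10 heavy atoms (7 carbon, 2 nitrogen, 1 oxygen; one six-membered aromatic ring with 2 hetero atoms), on an aromatic carbon.

Within the data shown here, the one measured step, a 1.1-fold lower number from compound 2 to compound 3 (0.04 log units; within the scatter), concerns a different place, the saturated chain carbon bound to an aromatic nitrogen, and so says nothing direct about exchanging the six-membered aromatic ring itself. Among the measured compounds shown here, no measured pair addresses the change from compound 1 to compound 4. With all three numbers close together, compound 4 is expected to fall in the same band: estimate 21 uL/min, range 10 uL/min to 45 uL/min. The expected step of a 1.1-fold lower number from compound 1 to compound 4 (0.06 log units; within the scatter) is therefore estimated to stay within the scatter.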

Compound 4, intrinsic clearance in a liver preparation (reported as CLH), per the amount of preparation that the assay uses: < 3 uL/min
Compound 4: a limit, no number; the forecaster's own chance of this, stated with the estimate: 5%; middle value at least 7.0-fold (0.84 log units) from the limit.
By their numbers in this assay, from the lowest: compounds 3, 2 and 1 (each within the scatter of the next). At a limit, below all of these: compound 4.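

In this assay, exchanging the group on the aromatic carbon opposite the ring nitrogen gives an at least 8.0-fold lower number from compound 1 to compound 4 (0.90 log units; beyond the scatter), the only step shown that lies beyond the scatter. Among these compounds, the one earlier step, a 1.1-fold lower number from compound 2 to compound 3 (0.04 log units; within the scatter), concerned a saturated chain carbon bound to an aromatic nitrogen, so the series now shows for the first time that this read-out can respond to a change at the aromatic carbon. Compound 4 gives a limit and not a number, so the size of the step has no upper bound here: the limit of < 3 uL/min in this assay, at which 1 of the 4 values shown sits.

The exchange replaces the whole group at once, so the contributions of the ring and of its attached atoms cannot be separated. From the compounds shown here alone, how an ethoxy group or a chlorine on the six-membered aromatic ring with 1 hetero atom would read remains open.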